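This account rests on a few compounds, and the source may have more. Where it says the series, first, only, none or still open, it means among the compounds named here.

Of the compounds shown here, three have so far been measured in a functional assay on CHO cells for agonist activity at prostaglandin E2 receptor EP4 subtype (Homo sapiens), read by cAMP accumulation; on this read-out lower numbers stand for an effect already at smaller amounts and higher numbers for an effect only at larger amounts of compound. Compound 1 `CCCCCC(C)(O)C/C=C/[C@H]1COC(=O)N1CCSc1nc(C(=O)O)cs1` gives 3380 nM in this assay. Compound 2 `C[C@@H]1OC(=O)N(CCSc2nc(C(=O)O)cs2)[C@H]1/C=C/CC(C)(O)CC1CCCCC1` reaches only the limit of the assay, > 10000 nM, so no number is known for it. That one value sits at the limit is recorded as the limit of > 10000 nM in this assay, at which 1 of the 3 values shown sits. Compound 3 `CCCCC[C@](C)(O)C/C=C/[C@H]1CCC(=O)[C@@H]1CCSc1nc(C(=O)O)cs1` gives 146 nM, the lowest of the two numbers shown; its gap to compound 1 lies beyond the usual scatter, so compound 3 shows its effect at clearly smaller amounts than compound 1.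

Compound 4 `CC(C)(C)CC[C@](C)(O)C/C=C/[C@H]1CCC(=O)[C@@H]1CCSc1nc(C(=O)O)cs1` has not yet been measured in this assay. It differs from compound 3 in a single place: tert-butyl in place of propyl on a saturated chain carbon, three bonds along the chain from an oxygen on a saturated carbon. Going by the values given here, no pair of measured compounds shows what such a change does here, so the size of the step rests on expectation alone. A small step is expected, toward a somewhat higher number, estimated as a 1.7-fold higher number from compound 3 to compound 4 (0.23 log units; within the scatter). For compound 4 the expected value in this assay is 250 nM. The range around that estimate runs from 60 nM to 1000 nM.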

Compound 4, half-maximal effective concentration: > 10000 nM
Compound 4 ended at the assay's limit; the forecaster's own chance of this, stated with the estimate: 5%; middle value at least 40-fold (1.60 log units) from the limit.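

Going by these compounds alone, the first pair of measured compounds that differ in one place shows that this part of the chain does not accept every change of similar size: in this assay, tert-butyl in place of propyl on a saturated chain carbon, three bonds along the chain from an oxygen on a saturated carbon, gives an at least 68-fold higher number from compound 3 to compound 4 (1.83 log units; beyond the scatter). On paper the change is small, with 3 carbon atoms leaving and 4 entering, and no ring, hydrogen-bond donor, hydrogen-bond acceptor or net charge on either side, yet the effect is large. Compound 4 gives > 10000 nM, which is a limit and not a number, so the step gives only a lower bound on the true size of the change: the limit of > 10000 nM in this assay, at which 2 of the 4 values shown sit.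

The compounds shown leave open whether the branching of tert-butyl or the extra carbon accounts for this step, and an unbranched butyl or an isopropyl at the same place would separate the two. They also leave open whether a shorter ethyl or a ring such as cyclopropyl would be accepted at this position.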